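Swapping the aminophenyl ester group for a chlorophenylethenyl chain

A few compounds are considered here, and "the series" means these few. Any claim that something is new, unique, unknown or untested is made for them only; others in the source may bear on it.

Compound 1 `COc1cc(C2Oc3cc([C@H]4Oc5cc(O)cc(O)c5C(=O)[C@@H]4O)ccc3OC2COC(=O)c2ccc(N)cc2)ccc1O` carries a 4-aminophenyl group on a carbonyl carbon whose other neighbour is the oxygen next to that carbonyl group. For the measured compounds named here, in a functional assay on liver (Rattus norvegicus, strain Sprague-Dawley) for inhibition, with a stated time of 1 h (on this read-out higher numbers stand for weaker inhibition and lower numbers for stronger inhibition), compound 1 gives 14300 nM, and the only other measured compound, compound 2 `COc1cc(C2Oc3cc([C@H]4Oc5cc(O)cc(O)c5C(=O)[C@@H]4O)ccc3OC2COC(=O)c2cccc(Cl)c2)ccc1O`, gives 14200 nM in this assay; the step of a 1.0-fold lower number from compound 1 to compound 2 (0.00 log units; within the scatter) lies within the scatter, so the two stand together. Going by the values given here, that single step is the only measured comparison bearing on compound 3 `COc1cc(C2Oc3cc([C@H]4Oc5cc(O)cc(O)c5C(=O)[C@@H]4O)ccc3OC2COC(=O)/C=C/c2ccc(Cl)cc2)ccc1O`, which differs from compound 1 as follows: 2-(4-chlorophenyl)ethenyl in place of 4-aminophenyl on a carbonyl carbon. Among the compounds with values here, the one measured change at this carbonyl carbon left the read-out unmoved, and nothing in these two numbers argues for a step beyond the scatter. Compound 3 is therefore expected to come out near its parent, with an expected step of a 1.1-fold lower number from compound 1 to compound 3 (0.04 log units; within the scatter). The estimate for compound 3 in this assay is 13000 nM, in the range 4000 nM to 40000 nM.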

Compound 3, half-maximal inhibitory concentration: 12000 nM
Compound 3: middle estimate off by 1.1-fold (0.03 log units), on the high side; measured number inside the range.
By their numbers in this assay, from the lowest: compounds 3, 2 and 1 (each within the scatter of the next).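

In this assay the 2-(4-chlorophenyl)ethenyl group, which brings a double bond outside aromatic rings and has no hydrogen-bond donor, gives a 1.2-fold lower number from compound 1 to compound 3 (0.08 log units; within the scatter) and also a 1.2-fold lower number from compound 2 to compound 3 (0.07 log units; within the scatter) when set against the 3-chlorophenyl group. For the compounds shown here, at this carbonyl carbon, three different groups now stand together, and the ethenyl link between the carbonyl and the aromatic ring is the first such link among them to show no step beyond the scatter. No measurement offered here accounts for why these three numbers stand together.

Going by these compounds, whether a group without an aromatic ring, such as a plain alkyl chain, or an aromatic ring bearing a carboxylic acid would also stand with these three remains open. So does the outcome of replacing the ester oxygen with an amide nitrogen, since all three compounds keep the same ester link on the shared core.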